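This account rests on a few compounds, and the source may have more. Where it says the series, first, only, none or still open, it means among the compounds named here.

Of the compounds shown here, three sharing one core have been measured in an assay on isolated protein for binding affinity to sphingosine 1-phosphate receptor 2 (Homo sapiens), read by surface plasmon resonance; a higher number here means weaker binding, a lower number tighter binding. Compound 1 `Cn1nc(C(F)(F)F)c2c(-c3ccccc3)cc(NNC(=O)Nc3cc(Cl)nc(Cl)c3)nc21` gives 940 nM. Compound 2 `COc1ccc(-c2cc(NNC(=O)Nc3cc(Cl)nc(OC)c3)nc3c2cnn3C)cc1` gives 1980 nM, the highest of the three numbers. Compound 3 `COc1cc(NC(=O)NNc2cc(-c3ccc(F)cc3)c3cnn(C)c3n2)cc(Cl)n1` gives 1650 nM. Within the data shown here, the only measured pair that differs in one place is compound 2 and compound 3, where fluoro in place of methoxy on an aromatic carbon gives a 1.2-fold lower number from compound 2 to compound 3 (0.08 log units; within the scatter). Among the measured compounds shown here, compound 1 differs from compound 2 in more than one place, so its two values show only that compound 1 sits at the lower end of the set and compound 2 at the upper end.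

Compound 4 `CCCOc1cc(NC(=O)NNc2cc(-c3ccc(OC)cc3)c3cnn(C)c3n2)cc(Cl)n1` differs from compound 2 by ethyl in place of hydrogen on a saturated chain carbon bound to an oxygen on an aromatic ring. For the measured compounds named here, no measured step touches this place, and the single measured step, from compound 2 to compound 3, is within the scatter. The expectation for compound 4 is therefore no step beyond the scatter, a 1.1-fold lower number from compound 2 to compound 4 (0.04 log units; within the scatter). Compound 4 is estimated at 1800 nM, within a range of 700 nM to 4500 nM.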

Compound 4, dissociation constant: 3140 nM
The estimate for compound 4 lay 1.7-fold (0.24 log units) below the measured number; the range from low to high includes it.
By their numbers in this assay, from the lowest: compounds 1, 3, 2 and 4 (each within the scatter of the next, the first and the last beyond it).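

Among these compounds, compound 4 gives the first reading at this place: in this assay, going from methoxy to propoxy on the aromatic ring gives a 1.6-fold higher number from compound 2 to compound 4 (0.20 log units; within the scatter) and so adds no step beyond the usual scatter. Among the compounds shown here, the earlier compounds left this place untouched, while the only earlier single-place step concerned a different change, fluoro in place of methoxy on an aromatic carbon. This one step shows that ethyl in place of hydrogen on the saturated chain carbon bound to that oxygen can be accommodated here without a clear shift in binding. Nothing available bears on why this step has the size it has.

Still open, on these data alone, is whether a longer chain such as butoxy, or a chain ending in an amine or a carboxylic acid, would move the number beyond the scatter. Also open, as far as these compounds go, is whether propoxy would behave the same way with the fluoro-bearing aromatic group of compound 3.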